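Compound 2 to compound 3 under a shared assay limit

The source may report more compounds than this note shows. Statements on the series, on what has been measured and on what is new or still open speak of the compounds shown alone.

Compound 1 (`COc1ccc(NCCNc2ccnc3cc(Cl)ccc23)cc1`) and compound 2 (`Clc1ccc2c(NCCNc3ccc(Br)cc3)ccnc2c1`) share one core and differ in a single group, with bromo in place of methoxy on an aromatic carbon. In a toxicity assay on Huh-7 cells (Homo sapiens) for cytotoxicity, read by MTT assay, with a stated time of 72 h (a higher number here means that more compound is tolerated, a lower number that less compound is tolerated), compound 1 gives > 100 ug/mL as a limit and not a number. In this assay compound 2 gives > 100 ug/mL as a limit too. Compound 2 therefore has no exact position, and the whole picture so far is the limit of > 100 ug/mL in this assay, at which 2 of the 2 values shown sit, with nothing finer to add. Going by the values given here, the only measured step is a step that the two limits leave unreadable from compound 1 to compound 2 and it offers no size to carry forward.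

Compound 3 (`Clc1ccc2c(NCCNc3ccccc3Cl)ccnc2c1`) departs from compound 2 in one place, as 2-chlorophenyl in place of 4-bromophenyl on an amine nitrogen shows in full. Among the compounds with values here, no measured step bears directly on this exchange of 2-chlorophenyl for 4-bromophenyl on an amine nitrogen. No step beyond the scatter is therefore expected in this assay and no direction can be given. The estimated change is a number no higher from compound 2 to compound 3 (the limit leaves the size open) on this reading. For compound 3 the estimate is 100 ug/mL with an expected range from 35 ug/mL to 200 ug/mL and a reading that is again only a limit would fit this expectation.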

Compound 3, half-maximal cytotoxic concentration: > 100 ug/mL
Compound 3 ended at the assay's limit; the forecaster's own chance of this, stated with the estimate: 60%; the middle value sits exactly at the limit.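

In this assay compound 3 gives > 100 ug/mL, which is a limit and not a number. No step from compound 2 to compound 3 can be read, because both stand at the same limit: the limit of > 100 ug/mL in this assay, at which 3 of the 3 values shown sit.

The compounds shown leave open how much of any of them the cells would tolerate, and whether the groups exchanged make any difference.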